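Dibutylamino to Methyl(phenyl)amino: Expected Inhibition of Compound 3

The compounds below may be only part of what the source reports. "The series", "measured", "known", "first", "only" and "open" are said of these compounds alone.

Measured so far:
Compound 1 `C=CCc1ccc(O)c(-c2cc(CC=C)cc(CN(CCC)CCC)c2O)c1` gives 6.3% in an assay on isolated protein for inhibition of Maltase-glucoamylase (Homo sapiens), with stated times of 15 min and 10 min, tested at 64 uM; a higher number here means more inhibition at the concentration tested (going by the name of the read-out), a lower number less inhibition.
Compound 2 `C=CCc1ccc(O)c(-c2cc(CC=C)cc(CN(CCCC)CCCC)c2O)c1` gives 8.2% in this assay.

Among the compounds with values here, compound 2 holds the higher of the two numbers, but its only neighbour, compound 1, sits a step away that is within the scatter: a number 1.9 percentage points higher from compound 1 to compound 2 (within the scatter). The two compounds cannot be told apart on these data.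

Compound 3 `C=CCc1ccc(O)c(-c2cc(CC=C)cc(CN(C)c3ccccc3)c2O)c1` has not yet been measured. It differs from compound 2 as follows: methyl(phenyl)amino in place of dibutylamino on a saturated chain carbon bound to an aromatic carbon. Within the data shown here, the one measured step, dibutylamino in place of dipropylamino, only lengthened the two chains on the nitrogen and gave a number 1.9 percentage points higher from compound 1 to compound 2 (within the scatter). Among the measured compounds shown here, no measured step brings an aromatic ring onto that nitrogen, so there is nothing here to suggest a change beyond the scatter either way. Compound 3 is therefore expected to give about 10% in this assay, between 0% and 25%, a step of a number 1.8 percentage points higher from compound 2 to compound 3 (within the scatter) that is expected to stay within the scatter.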

Compound 3, a percentage reported as inhibition, at one concentration (the size of the read-out at that concentration, not a potency): 15.5%
Estimate against measurement, compound 3: 5.5 percentage points below, within the range that was stated.
By their numbers in this assay, from the lowest: compounds 1, 2 and 3 (each within the scatter of the next).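

Putting methyl(phenyl)amino on a saturated chain carbon bound to an aromatic carbon gives, in this assay, a number 7.3 percentage points higher from compound 2 to compound 3 (within the scatter), and the comparison with the dipropylamino compound gives a number 9.2 percentage points higher from compound 1 to compound 3 (within the scatter). Within the data shown here, this is the first sign that replacing two open chains with a group holding a six-membered aromatic ring of carbon only does not shift the number beyond the usual scatter, so the three compounds cannot be told apart. Nothing available offers an explanation for this result.

From the compounds shown here alone, it remains open whether a piperidine ring, a primary amine or a chain ending in a carboxylic acid in this place would produce a step beyond the scatter. Each number also comes from a single concentration, so the potency of these compounds remains open too.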